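Compound 4: 3-nitrophenyl in place of 4-methylphenyl

This account rests on a few compounds, and the source may have more. Where it says the series, first, only, none or still open, it means among the compounds named here.

In a physicochemical assay for lipophilicity, read by LC-MS, measured as octanol-water partition, with a stated time of 2 h, at pH 7.4, tested at 1 uM (a lower number here means a more polar compound, a higher number a more lipophilic compound), compound 1 (`Cc1cccc(-c2ccc(O[C@H]3O[C@H](CO)[C@@H](O)[C@H](O)[C@@H]3O)c(Cl)c2)c1`) gives 3 and compound 2 (`OC[C@H]1O[C@H](Oc2ccc(-c3ccc(Cl)cc3)cc2Cl)[C@@H](O)[C@@H](O)[C@@H]1O`) gives 3.3, while compound 3 (`Cc1ccc(-c2ccc(O[C@H]3O[C@H](CO)[C@@H](O)[C@H](O)[C@@H]3O)c(Cl)c2)cc1`) gives 3.3 at the same digits as compound 2. Compound 1 lies within the scatter of both. Compound 4 (`O=[N+]([O-])c1cccc(-c2ccc(O[C@H]3O[C@H](CO)[C@@H](O)[C@H](O)[C@@H]3O)c(Cl)c2)c1`) has 3-nitrophenyl in place of 4-methylphenyl on an aromatic carbon. The step between the two methylphenyl compounds (a number 0.30 log units higher from compound 1 to compound 3 (within the scatter)), the step to the chlorophenyl compound (a number 0.30 log units higher from compound 1 to compound 2 (within the scatter)) and the exchange of chloro for methyl (no change at the digits printed from compound 2 to compound 3 (within the scatter)) all lie within the scatter. None of them brings in a 3-nitrophenyl group, so the expectation rests on the structural difference alone. A fall beyond the scatter is expected (a number 0.60 log units lower from compound 3 to compound 4 (beyond the scatter)). The estimate for compound 4 is 2.7 (expected range 2.3 to 3.1).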

Compound 4, distribution coefficient: 2.4
For compound 4 the middle estimate is 0.30 log units above the measured one, within the range that was stated.
By their numbers in this assay, from the lowest: compound 4; then compounds 1, 2 and 3 (each within the scatter of the next).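

In this assay, going by these compounds alone, this place on the core proves sensitive for the first time: the earlier exchanges there all stayed within the scatter, whereas 3-nitrophenyl gives a number 0.90 log units lower from compound 3 to compound 4 (beyond the scatter) and also a number 0.90 log units lower from compound 2 to compound 4 (beyond the scatter) against 4-chlorophenyl. The fall holds with the substitution position unchanged, since nitro in place of methyl gives a number 0.60 log units lower from compound 1 to compound 4 (beyond the scatter) as a single exchange. Nothing available accounts for this fall. Whether it is particular to nitro stays open, as no compound shown carries a nitrile, an amine or a carboxylic acid at this place.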